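Changing the sulfonyl aryl group of compound 3

This account rests on a few compounds, and the source may have more. Where it says the series, first, only, none or still open, it means among the compounds named here.

In a functional assay on MCF7 cells (Homo sapiens) for antiproliferative activity, read by MTT assay, with a stated time of 24 h (a lower number here means a stronger inhibitor, a higher number a weaker inhibitor), compound 3 (`Cc1ccc(C)c(S(=O)(=O)n2c(-c3cn(-c4ccccc4)nc3-c3ccc(C(F)(F)F)cc3)nc3ccccc32)c1`) gives 170 nM, the lowest of the three measured numbers. Compound 4 (`O=S(=O)(c1ccc(F)cc1)n1c(-c2cn(-c3ccccc3)nc2-c2ccc(C(F)(F)F)cc2)nc2ccccc21`) has 4-fluorophenyl in place of 2,5-dimethylphenyl on a sulfonyl sulfur. Going by the values given here, the only measured step starts from compound 1 (`FC(F)(F)c1ccc(-c2nn(-c3ccccc3)cc2-c2nc3ccccc3[nH]2)cc1`), which gives 6330 nM. That large step, a 37-fold lower number from compound 1 to compound 3 (1.57 log units; beyond the scatter), adds the whole (2,5-dimethylphenyl)sulfonyl group, so it does not test this swap. Compound 2 (`O=S(=O)(c1ccc(F)cc1)n1c(-c2cn(-c3ccccc3)nc2-c2ccc(F)cc2)nc2ccccc21`) carries the (4-fluorophenyl)sulfonyl group and gives 3670 nM, but it also differs from compound 3 elsewhere, so it offers only a hint. On that hint, a moderate rise in this assay is expected, a 4.1-fold higher number from compound 3 to compound 4 (0.61 log units; beyond the scatter). Compound 4 is estimated at 700 nM, with an expected range of 200 nM to 3000 nM.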

Compound 4, half-maximal inhibitory concentration: 3120 nM
The estimate for compound 4 lay 4.5-fold (0.65 log units) below the measured number, and the stated range ends below it.
By their numbers in this assay, from the lowest: compound 3; then compounds 4, 2 and 1 (each within the scatter of the next, the first and the last beyond it).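

In this assay the aryl group on the sulfonyl sulfur proves decisive: 4-fluorophenyl in place of 2,5-dimethylphenyl loses most of the gain (an 18-fold higher number from compound 3 to compound 4 (1.26 log units; beyond the scatter)). Trifluoromethyl in place of fluoro on an aromatic carbon leaves no difference that can be told from scatter (a 1.2-fold lower number from compound 2 to compound 4 (0.07 log units; within the scatter)). Adding (4-fluorophenyl)sulfonyl to the bare core achieves only a modest step (a 2.0-fold lower number from compound 1 to compound 4 (0.31 log units; beyond the scatter)), far smaller than the one (2,5-dimethylphenyl)sulfonyl gives (a 37-fold lower number from compound 1 to compound 3 (1.57 log units; beyond the scatter)).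

No measured evidence accounts for this gap. From the compounds shown here alone, how a single methyl, a methoxy or an amine on that aryl ring would behave remains open.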